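Swapping a thiophene for a methylfuran on the dihydropyridine core

A few compounds are considered here, and "the series" means these few. Any claim that something is new, unique, unknown or untested is made for them only; others in the source may bear on it.

Measured so far:
Compound 1, `COc1ccccc1C1C(C#N)=C(N)N(c2cc(OC)c(OC)c(OC)c2)C2=C1C(=O)CC(C)(C)C2`: 65%
Compound 2, `COc1cc(N2C(N)=C(C#N)C(c3cccs3)C3=C2CC(C)(C)CC3=O)cc(OC)c1OC`: 10%
Compound 3, `COc1cc(N2C(N)=C(C#N)C(c3ccc(C)cc3)C3=C2CC(C)(C)CC3=O)cc(OC)c1OC`: 50%

In a functional assay on Ehrlich cells (Mus musculus) for cytotoxicity, tested at 25 ug/mL (on this read-out higher numbers stand for a stronger effect at the one concentration tested and lower numbers for a weaker effect), compound 2 stands lowest of the three measured compounds; its nearest neighbour is compound 3, and its furthest is compound 1. Compound 4, `COc1cc(N2C(N)=C(C#N)C(c3ccc(C)o3)C3=C2CC(C)(C)CC3=O)cc(OC)c1OC`, has not yet been measured. It differs from compound 2 in one place: 5-methylfuran-2-yl in place of thiophen-2-yl on a saturated ring carbon.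

Two measured steps start from the same thiophen-2-yl group on the same saturated ring carbon and so bear on this change. Replacing it with 2-methoxyphenyl gave a number 55 percentage points lower from compound 1 to compound 2 (beyond the scatter) read backwards, and replacing it with 4-methylphenyl gave a number 40 percentage points higher from compound 2 to compound 3 (beyond the scatter). Both replacements with a six-membered ring raised the activity strongly. The group entering here is again one five-membered aromatic ring with 1 hetero atom, so a rise is expected, but a smaller one than those seen with the six-membered rings. For compound 4 the expected step is a number 15 percentage points higher from compound 2 to compound 4 (beyond the scatter), and the estimated activity of compound 4 is 25%, within a range from 5% to 50%.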

Compound 4, a percentage reported as activity, at one concentration (the size of the read-out at that concentration, not a potency): 31%
Compound 4: the middle estimate sits 6 percentage points below what was measured; the range from low to high includes it.
By their numbers in this assay, from the lowest: compound 2; then compound 4; then compound 3; then compound 1.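

In this assay two groups that are each one five-membered aromatic ring with 1 hetero atom do not count as equal at this saturated ring carbon: 5-methylfuran-2-yl in place of thiophen-2-yl gives a number 21 percentage points higher from compound 2 to compound 4 (beyond the scatter) on the shared core. The gain does not reach the six-membered rings, with a number 19 percentage points lower from compound 3 to compound 4 (beyond the scatter) on leaving 4-methylphenyl and a number 34 percentage points lower from compound 1 to compound 4 (beyond the scatter) on leaving 2-methoxyphenyl, so among these four compounds both five-membered groups lie below both six-membered groups, and no compound goes against that order. Nothing shown here gives a reason for these steps.

From the compounds shown here alone, this change swaps sulfur for oxygen and adds a methyl group in one move, so the share of each stays unknown; furan-2-yl and 5-methylthiophen-2-yl would separate them. Also open, going by these compounds, is where a plain phenyl or a pyridin-3-yl group would fall in this order.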